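The source may hold more compounds than are shown below. What is called first, only, known or untested is meant among the compounds shown, and "the series" means these compounds.

Working notes on the series in a functional assay on HeLa cells (Homo sapiens) for cytotoxicity; a higher number here means that more compound is tolerated, a lower number that less compound is tolerated.

Compound 1, `Nc1ncnc2c1ncn2CC(O)C(=O)OCCO`, is the reference point. In this assay compound 1 gives > 400 ug/mL, which is a limit of the assay and not a number. Compound 2, `CC(C)COC(=O)C(O)Cn1cnc2c(N)ncnc21`, gives > 400 ug/mL in this assay, again only a limit. Compound 3, `CCC(C)OC(=O)C(O)Cn1cnc2c(N)ncnc21`, gives > 400 ug/mL in this assay, also a limit. All three values sit at the limit of > 400 ug/mL in this assay, at which 3 of the 3 values shown sit. The steps a step that the two limits leave unreadable from compound 1 to compound 2, a step that the two limits leave unreadable from compound 1 to compound 3 and a step that the two limits leave unreadable from compound 2 to compound 3 are therefore unreadable: the two limits hide whether the change on the oxygen next to a carbonyl group alters how much compound is tolerated.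

Compound 4, `CCOC(=O)C(O)Cn1cnc2c(N)ncnc21`, is still to be measured. Compound 4 differs from compound 1 as follows: hydrogen in place of hydroxy on a saturated chain carbon, two bonds along the chain from an oxygen next to a carbonyl group. Among the measured compounds shown here, none of the measured steps touches this hydroxy; the nearest, a step that the two limits leave unreadable from compound 1 to compound 2 and a step that the two limits leave unreadable from compound 1 to compound 3, change the chain on the oxygen next to a carbonyl group and give no readable size. Since every value shown is a limit, no step beyond the scatter is expected, and a limit is the likely outcome once more. The step of a number no higher from compound 1 to compound 4 (the limit leaves the size open) is expected to be small. Compound 4 is estimated at 400 ug/mL, with a range from 150 ug/mL to 800 ug/mL.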

Compound 4, minimum cytotoxic concentration: > 400 ug/mL
Compound 4 was reported as a limit (the forecaster's own chance of this, stated with the estimate: 80%); the middle value sits exactly at the limit.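

In this assay compound 4 gives > 400 ug/mL, a limit of the assay and not a number. The steps joining compound 4 to compound 1, compound 2 and compound 3 therefore cannot be read, as all four values sit at one limit: the limit of > 400 ug/mL in this assay, at which 4 of the 4 values shown sit.

The compounds shown leave open whether the hydroxy or the chain on the oxygen next to a carbonyl group alters how much compound is tolerated.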